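The source may report more compounds than this note shows. Statements on the series, on what has been measured and on what is new or still open speak of the compounds shown alone.

Compound 1 `COc1ccc(CNc2nc(SC)nc3ncccc23)cc1`: > 100000 nM, a limit of the assay.
Compound 2 `CSc1nc(NCCCCCO)c2ccccc2n1`: > 100000 nM, a limit of the assay.
Compound 3 `[SeH]c1nc([SeH])c2ccccc2n1`: 2990 nM.

The measurement here is a functional assay on CCRF-CEM cells (Homo sapiens) for cytotoxicity, read by MTT assay, with a stated time of 72 h; on this read-out higher numbers stand for weaker inhibition of growth and lower numbers for stronger inhibition of growth. Compound 3 is the only one of the three that gives a number, 2990 nM. Compound 2 stands at the limit of > 100000 nM in this assay, at which 2 of the 3 values shown sit, so for compound 2 only the limit > 100000 nM is known and not a value. Among the compounds with values here, no pair of measured compounds differs in a single place, so no measured step is available to guide the next change.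

Compound 4 `CSc1nc(NCCCc2ccccc2)c2ccccc2n1` shares the core of compound 2 and differs from it in one place: phenyl in place of 2-hydroxyethyl on a saturated chain carbon, three bonds along the chain from a nitrogen on an aromatic ring. Without a measured step of this kind, the expectation rests on compound 2 alone, which sits at a limit, so the step is estimated as a move from compound 2 toward stronger inhibition of growth of modest size, within an at least 1.6-fold lower number from compound 2 to compound 4 (0.22 log units; that floor lies within the scatter), though a result that remains at the limit is nearly as likely. Compound 4 is therefore estimated at 60000 nM in this assay, with the expected range running from 10000 nM to 200000 nM.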

Compound 4, concentration for 50% growth inhibition: 39500 nM
Beside the measured number, compound 4's estimate is 1.5-fold (0.18 log units) above it, and the stated range covers the measured number.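

This position, on a saturated chain carbon, three bonds along the chain from a nitrogen on an aromatic ring, now proves open to change: in this assay, phenyl in place of 2-hydroxyethyl gives an at least 2.5-fold lower number from compound 2 to compound 4 (0.40 log units; beyond the scatter). Within the data shown here, it is the first single change that can be read here, and it brings this side chain on the shared core from a limit to a measured number. The true size of the step remains unknown because compound 2 has only a limit and not a value, so the printed step is a minimum: the limit of > 100000 nM in this assay, at which 2 of the 4 values shown sit.

The change does several things at once, since the group that leaves has a hydrogen-bond donor and acceptor while the larger group that enters has neither and adds an aromatic ring, and one step cannot tell these apart. A cyclohexyl ring, a plain butyl chain or a terminal amine in the same place would help to separate them, while compound 3, at 2990 nM, differs from compound 4 in more than one place and so cannot show what would carry this series further.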